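Methyl to Phenyl on the Five-Membered Ring of Compound 1

This account rests on a few compounds, and the source may have more. Where it says the series, first, only, none or still open, it means among the compounds named here.

Compound 1 `COc1ccc2[nH]c(-c3nc(C)no3)cc2c1`: 19900 nM
Compound 2 `Cc1noc(-c2cc3cc(Cl)ccc3[nH]2)n1`: 21600 nM

In a functional assay on Jurkat cells (Homo sapiens) for antiproliferative activity, read by WST assay, with a stated time of 72 h (on this read-out lower numbers stand for stronger inhibition and higher numbers for weaker inhibition), compound 1 gives 19900 nM, and compound 2 gives 21600 nM. Going by the values given here, compound 1 holds the lower of the two numbers, but the only step connecting them, a 1.1-fold higher number from compound 1 to compound 2 (0.04 log units; within the scatter), is within the scatter, so the two compounds cannot be told apart on this read-out.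

Compound 3 `COc1ccc2[nH]c(-c3nc(-c4ccccc4)no3)cc2c1` is built from compound 1 by one change: phenyl in place of methyl on an aromatic carbon. The group sits on an aromatic carbon of a five-membered aromatic ring with 2 nitrogen and 1 oxygen, between two ring nitrogen atoms. Among the compounds with values here, no measured step touches this position; the single known step, from compound 1 to compound 2, changes a different part of the molecule and was itself within the scatter. There is therefore nothing in the numbers to suggest a move in either direction, and the expectation for compound 3 is a value close to that of compound 1, with a wide range to allow for the untested change.

The expected value for compound 3 in this assay is 15000 nM, between 4000 nM and 60000 nM. This estimate corresponds to the step of a 1.3-fold lower number from compound 1 to compound 3 (0.12 log units; within the scatter).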

Compound 3, half-maximal inhibitory concentration: > 50000 nM
Compound 3 ended at the assay's limit (the forecaster's own chance of this, stated with the estimate: 15%); middle value at least 3.3-fold (0.52 log units) from the limit.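

Compound 3 gives > 50000 nM in this assay, and this is a limit of the assay and not a number. The earlier step from compound 1 to compound 2 changed a different part of the molecule and stayed within the scatter, whereas this change, on the aromatic carbon between two ring nitrogen atoms, gives an at least 2.5-fold higher number from compound 1 to compound 3 (0.40 log units; beyond the scatter), so this position is the first shown to respond, with phenyl in place of methyl weakening inhibition. The step marks only the minimum size of this loss, not its full size: the limit of > 50000 nM in this assay, at which 1 of the 3 values shown sits.

With only methyl and phenyl shown at this carbon, it remains open whether inhibition falls gradually as the group grows or whether something particular to phenyl matters, a question that an ethyl group or a cyclopropyl group here could help to answer. Going by these compounds, it also remains open whether an amine or a carboxylic acid at this carbon would restore inhibition, and whether phenyl has the same effect when chloro replaces methoxy, as in compound 2.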